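Aryl swap in a series held at the limit

The compounds below may be only part of what the source reports. "The series", "measured", "known", "first", "only" and "open" are said of these compounds alone.

In a functional assay on MDA-MB-231 cells (Homo sapiens) for antiproliferative activity, read by MTT assay, with a stated time of 48 h (on this read-out lower numbers stand for stronger inhibition and higher numbers for weaker inhibition), compound 1 (`COc1ccccc1-n1cc(COC(=O)/C(C)=C/CC/C(C)=C/CC/C(C)=C/CC[C@@H]2[C@@]3(C)CCC(=O)C(C)(C)[C@H]3CC[C@@]2(C)O)nn1`) gives > 150000 nM, which is a limit and not a number. Compound 2 (`C/C(=C\CC/C(C)=C/CC[C@@H]1[C@@]2(C)CCC(=O)C(C)(C)[C@H]2CC[C@@]1(C)O)CC/C=C(\C)C(=O)OCc1cn(-c2ccc(C(F)(F)F)cc2)nn1`) gives > 150000 nM, also a limit. Compound 3 (`COc1ccc(-n2cc(COC(=O)/C(C)=C/CC/C(C)=C/CC/C(C)=C/CC[C@@H]3[C@@]4(C)CCC(=O)C(C)(C)[C@H]4CC[C@@]3(C)O)nn2)cc1`) gives > 150000 nM, again a limit, so compound 3 has no measured position in the series.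

Compound 4 (`C/C(=C\CC/C(C)=C/CC[C@@H]1[C@@]2(C)CCC(=O)C(C)(C)[C@H]2CC[C@@]1(C)O)CC/C=C(\C)C(=O)OCc1cn(-c2cccc(F)c2)nn1`) carries 3-fluorophenyl in place of 4-methoxyphenyl on an aromatic nitrogen.

The closest evidence is the exchange of aryl groups at this same nitrogen: a step that the two limits leave unreadable from compound 1 to compound 2, a step that the two limits leave unreadable from compound 1 to compound 3 and a step that the two limits leave unreadable from compound 2 to compound 3. None of these has a readable size, so none gives a direction. The only firm observation is the limit of > 150000 nM in this assay, at which 3 of the 3 values shown sit. No step beyond the scatter is therefore expected, and a further report of only a limit is the likeliest outcome. The expected step is a number no higher from compound 3 to compound 4 (the limit leaves the size open). The estimate for compound 4 is 150000 nM, with an expected range from 70000 nM to 300000 nM.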

Compound 4, half-maximal inhibitory concentration: 144000 nM
For compound 4 the middle estimate is 1.0-fold (0.02 log units) above the measured one; measured number inside the range.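

In this assay, among these compounds, compound 4 gives 144000 nM, so 3-fluorophenyl on this aromatic nitrogen yields the first number, and the steps to it have only small floors: an at least 1.0-fold lower number from compound 3 to compound 4 (0.01 log units; that floor lies within the scatter), an at least 1.0-fold lower number from compound 2 to compound 4 (0.01 log units; that floor lies within the scatter) and an at least 1.0-fold lower number from compound 1 to compound 4 (0.01 log units; that floor lies within the scatter). None of the three floors exceeds the scatter, so no aryl exchange at this position is yet shown to change the read-out by a real margin. For compound 1, compound 2 and compound 3, the comparison rests on a limit and not a number: the limit of > 150000 nM in this assay, at which 3 of the 4 values shown sit.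

On these data alone, the true size of each step remains open, as does whether the fluorine matters at all. Also open, as far as these compounds go, is whether an aryl ring carrying an amine or a carboxylic acid at this nitrogen would give a step beyond the scatter.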